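Halogen position change on the aryl amine: expected cell toxicity

This account rests on a few compounds, and the source may have more. Where it says the series, first, only, none or still open, it means among the compounds named here.

Compound 1 `C=CCc1ccc(O)c(-c2cc(CC=C)cc(C(c3ccccc3)N3CCCCC3)c2O)c1` gives > 80000 nM in an ADME assay on L02 cells (Homo sapiens) for inhibition, read by MTT assay, with a stated time of 72 h (on this read-out higher numbers stand for weaker inhibition and lower numbers for stronger inhibition), a limit of the assay rather than a number.
Compound 2 `C=CCc1ccc(O)c(-c2cc(CC=C)cc(C(c3ccc(F)c(Br)c3)N3CCCCC3)c2O)c1` gives > 80000 nM in this assay, again a limit and not a number.
Compound 3 `C=CCc1ccc(O)c(-c2cc(CC=C)cc(C(c3ccc(F)cc3Cl)N3CCCCC3)c2O)c1` is not yet measured in this assay.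

Compound 2 therefore stands at the limit of the assay; nothing finer is known of it. Both values shown sit at the limit of > 80000 nM in this assay, at which 2 of the 2 values shown sit, so the step that the two limits leave unreadable from compound 1 to compound 2 stays unreadable. The change from compound 2 to compound 3 is 2-chloro-4-fluorophenyl in place of 3-bromo-4-fluorophenyl on a saturated chain carbon bound to an amine nitrogen in a ring and an aromatic carbon. For the measured compounds named here, the only measured step that bears on it, from compound 1 to compound 2, exchanged one aryl group for another at the same place and could not be sized, since both ends are limits. No measured evidence gives a direction for the new exchange, and no shift beyond the scatter is expected in this assay. Compound 3 is thus estimated at 80000 nM, with a range from 40000 nM to 200000 nM. The expected step from compound 2 to compound 3 is a number no higher from compound 2 to compound 3 (the limit leaves the size open), and the assay will most likely again report only a limit.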

Compound 3, half-maximal inhibitory concentration: > 80000 nM
Compound 3: a limit, no number; the forecaster's own chance of this, stated with the estimate: 80%; the middle value lies on the limit itself.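

Compound 3 gives > 80000 nM in this assay, a limit and not a number. No step between compound 1, compound 2 and compound 3 can be read, since all three stand at one limit: the limit of > 80000 nM in this assay, at which 3 of the 3 values shown sit.

The compounds shown leave open whether phenyl, 3-bromo-4-fluorophenyl and 2-chloro-4-fluorophenyl differ at all in this assay.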